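Swapping methoxymethyl for phenyl on a triple-bonded carbon

A few compounds are considered here, and "the series" means these few. Any claim that something is new, unique, unknown or untested is made for them only; others in the source may bear on it.

Measured in an ADME assay on L1210/0 cells (Mus musculus) for cytotoxicity, with a stated time of 48 h; a higher number here means a weaker inhibitor, a lower number a stronger inhibitor:
compound 1 `O=c1[nH]c(=O)n([C@H]2C[C@H](O)[C@@H](CO)O2)cc1/C=C/I`: 63900 nM
compound 2 `O=c1[nH]c(=O)n([C@H]2C[C@H](O)[C@@H](CO)O2)cc1C#CCO`: > 200000 nM (a limit)
compound 3 `COCC#Cc1cn([C@H]2C[C@H](O)[C@@H](CO)O2)c(=O)[nH]c1=O`: > 200000 nM (a limit)

The value of compound 3, > 200000 nM, is a limit and not a number. It stands at the limit of > 200000 nM in this assay, at which 2 of the 3 values shown sit. Compound 4 `O=c1[nH]c(=O)n([C@H]2C[C@H](O)[C@@H](CO)O2)cc1C#Cc1ccccc1` has phenyl in place of methoxymethyl on a triple-bonded carbon. Within the data shown here, the steps that bear on this are an at least 3.1-fold higher number from compound 1 to compound 2 (0.49 log units; beyond the scatter) and an at least 3.1-fold higher number from compound 1 to compound 3 (0.49 log units; beyond the scatter), both beyond the scatter, while a step that the two limits leave unreadable from compound 2 to compound 3 tells nothing. None of them brings in phenyl, so the guide is weak. Only compound 1, at 63900 nM, gives a true number, so a modest fall in the number is expected, or none. The expected change is an at least 1.5-fold lower number from compound 3 to compound 4 (0.18 log units; that floor lies within the scatter). For compound 4 the estimate is 130000 nM, with an expected range of 40000 nM to 200000 nM.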

Compound 4, half-maximal inhibitory concentration: > 200000 nM
Compound 4 gave a limit, no number (the forecaster's own chance of this, stated with the estimate: 50%); middle value at least 1.5-fold (0.18 log units) from the limit.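

In this assay, compound 4 gives > 200000 nM, which is a limit, so a six-membered aromatic ring on the triple-bonded carbon yields no readable number, just as the smaller open chains did. Replacing 2-iodoethenyl with 2-phenylethynyl gives an at least 3.1-fold higher number from compound 1 to compound 4 (0.49 log units; beyond the scatter). The steps among compound 2, compound 3 and compound 4 cannot be read, and these compounds share one ceiling: the limit of > 200000 nM in this assay, at which 3 of the 4 values shown sit.

From the compounds shown here alone, how far apart these three compounds truly lie stays open. Also open, going by these compounds, is whether an amine or a longer alkyl chain on the triple-bonded carbon would give a measurable value.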